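Tetrazolylacetamide series: cyclopropyl replacing pyridin-2-yl on the tetrazole

The source may hold more compounds than are shown below. What is called first, only, known or untested is meant among the compounds shown, and "the series" means these compounds.

Measured so far:
- Compound 1, `O=C(Cn1nnc(-c2ccccc2)n1)NC1CC2CCC1C2`: 1980 nM
- Compound 2, `Cc1cc(NC(=O)Cn2nnc(-c3ccccc3)n2)n(Cc2ccccc2)n1`: 495 nM
- Compound 3, `Cc1cc(NC(=O)Cn2nnc(-c3ccccn3)n2)n(C2CCCCC2)n1`: 14600 nM

In an assay on HEK293 cells for activation of Kir3.1/Kir3.2 (Homo sapiens), read by thallium flux (a higher number here means that more compound is needed for the effect, a lower number that less compound is needed), compound 3 gives the highest of the three numbers; its gaps to compound 1 and to compound 2 both lie beyond the scatter, so compound 3 is the least potent of the three.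

Compound 4, `Cc1cc(NC(=O)Cn2nnc(C3CC3)n2)n(C2CCCCC2)n1`, is not yet measured. Its change from compound 3 is cyclopropyl in place of pyridin-2-yl on an aromatic carbon. Going by the values given here, no step between measured compounds is available for this change, so the expectation rests on compound 3 alone. A step toward a lower number, of modest size and possibly not beyond the scatter, is expected as a 2.1-fold lower number from compound 3 to compound 4 (0.32 log units; beyond the scatter). Compound 4 is estimated at 7000 nM, within 1500 nM to 30000 nM.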

Compound 4, half-maximal effective concentration: > 3000 nM
Compound 4: a limit, no number; the forecaster's own chance of this, stated with the estimate: 10%; the middle value does not contradict the limit.
By their numbers in this assay, from the lowest: compound 2; then compound 1; then compound 3.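

In this assay, going by these compounds alone, compound 4 gives > 3000 nM, which is a limit and not a number, so no step from compound 3 to compound 4 can be read. On these data alone, whether cyclopropyl in place of pyridin-2-yl lowers or raises the number stays open.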